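Swapping a Methyl for Two Chlorines on the Benzyl Arm

The source may report more compounds than this note shows. Statements on the series, on what has been measured and on what is new or still open speak of the compounds shown alone.

Compound 2 `CCN(Cc1cccc(C)c1)c1cc(C)nc2c(-c3cnc(N(C)C)cc3C)c(C)nn12` and compound 1 `CCCC(CCC)Nc1cc(C)nc2c(-c3cnc(N(C)C)cc3C)c(C)nn12` share one core and differ in the group on the ring nitrogen. In an assay on CHO cells for binding affinity to corticotropin-releasing factor receptor 1 (Homo sapiens) (a higher number here means a weaker inhibitor, a lower number a stronger inhibitor), compound 2 gives 2.4 nM and compound 1 gives 4.8 nM; these two numbers sit within the usual scatter of each other, so neither can be called the stronger binder. Compound 3 `CCN(Cc1ccc(Cl)c(Cl)c1)c1cc(C)nc2c(-c3cnc(N(C)C)cc3C)c(C)nn12` carries 3,4-dichlorophenyl in place of 3-methylphenyl on a saturated chain carbon bound to a nitrogen on an aromatic ring. For the measured compounds named here, no measured pair shows this change, so the expectation rests on these two numbers alone. The step is expected to be small, a 1.7-fold higher number from compound 2 to compound 3 (0.22 log units; within the scatter), none beyond the scatter. Compound 3 is expected to give 4 nM, within 1.2 nM to 13 nM.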

Compound 3, inhibition constant: 2.5 nM
Beside the measured number, compound 3's estimate is 1.6-fold (0.20 log units) above it; measured number inside the range.
By their numbers in this assay, from the lowest: compounds 2, 3 and 1 (each within the scatter of the next).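

Putting 3,4-dichlorophenyl in place of 3-methylphenyl gives a 1.0-fold higher number from compound 2 to compound 3 (0.02 log units; within the scatter) in this assay and so leaves the two compounds indistinguishable. For the compounds shown here, this is the first direct comparison at this position, and it shows that the benzyl arm can carry either two chlorines or one methyl with no difference that can be read from these numbers. No supporting measurement explains why the two groups read alike.

Still open, going by these compounds, is how an amine or a carboxylic acid on this benzyl ring would read, and whether a single chlorine would match the two chlorines.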